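One More Carbon on the Chain of Compound 3

The compounds below may be only part of what the source reports. "The series", "measured", "known", "first", "only" and "open" are said of these compounds alone.

Three ureas have been measured in an ADME assay on the whole organism with Oryza sativa as the target, tested at 0.1 uM; on this read-out lower numbers stand for a stronger effect and higher numbers for a weaker effect at the one concentration tested. Compound 1 `Cc1cccc(NC(=O)N[C@@H](C)c2ccccc2)c1` gives 99%. Compound 2 `CCc1cccc(NC(=O)N[C@@H](C)c2ccccc2)c1` differs from compound 1 by methyl in place of hydrogen on a saturated chain carbon bound to an aromatic carbon; in this read-out compound 2 gives 100%, and the step of a number 1 percentage points higher from compound 1 to compound 2 (within the scatter) is a small one. Compound 3 `CCCCCc1ccc(NC(=O)N[C@H](C)c2ccccc2)cc1` gives 100%; it sits level with compound 2 at the digits shown, and the two numbers from compound 3 and compound 1 lie within the scatter of each other, so no order among the three can be read from this assay. The difference between the core of compound 3 and the core of compound 1 is not broken down here.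

Compound 4 `CCCCCCc1ccc(NC(=O)N[C@H](C)c2ccccc2)cc1` has not been measured. It differs from compound 3 by methyl in place of hydrogen on a saturated chain carbon, five bonds along the chain from an aromatic carbon. For the measured compounds named here, this is the same kind of change as the one from compound 1 to compound 2, though not the same: in the earlier pair the carbon that receives the methyl is bound to an aromatic carbon, whereas in compound 4 it is five bonds along the chain from an aromatic carbon. Because the earlier step of a number 1 percentage points higher from compound 1 to compound 2 (within the scatter) left the read-out essentially unchanged, and because compound 3 already gives 100%, the expected step is no change at the digits printed from compound 3 to compound 4 (within the scatter), with no room above the present level. Compound 4 is thus estimated at 100% in this assay, within 90% to 100%.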

Compound 4, a percentage reported as activity, at one concentration (the size of the read-out at that concentration, not a potency): 100%
Compound 4: the middle estimate sits on the measured number at the digits printed, and the stated range covers the measured number.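

In this assay the new result is no change at the digits printed from compound 3 to compound 4 (within the scatter). Set beside the earlier step, methyl in place of hydrogen on a saturated chain carbon gives the same reading on both cores, as far as this read-out can tell: the same change on two cores in this assay, a number 1 percentage points higher (within the scatter) from compound 1 to compound 2 and no change at the digits printed (within the scatter) from compound 3 to compound 4, 1 percentage points apart, within the scatter of two such steps

This does not show that the change is without effect wherever it is made, or that the agreement would hold on other cores in the series. The carbon that receives the methyl is bound to an aromatic carbon in compound 2 and lies five bonds along the chain from an aromatic carbon in compound 4, so only these two places on these two cores are covered, and neither step shows the change moving the number at the single concentration tested.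

The compounds shown leave open whether any change in this series moves the read-out away from the level seen here, since all four numbers lie within the scatter of one another. They also leave open what a longer chain, or a chain carrying a carboxylic acid or an amine, would give in this assay.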